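A few compounds are considered here, and "the series" means these few. Any claim that something is new, unique, unknown or untested is made for them only; others in the source may bear on it.

Measured compounds:
compound 1 `NC(=O)Nc1sc(-c2ccc(C(=O)N3CCOCC3)cc2)cc1C(=O)N[C@H]1CCCNC1` – 610 nM
compound 2 `NC(=O)Nc1sc(-c2ccccc2)cc1C(=O)NC1CCOCC1` – "not determined" (no result reported)

The study compares compound 1 with compound 2 and with the unmeasured compound 3 `NC(=O)Nc1sc(-c2ccc(C(N)=O)cc2)cc1C(=O)N[C@H]1CCCNC1`. Among the compounds with values here, in a functional assay on HT-29 cells (Homo sapiens) (a higher number here means that more compound is needed for the effect, a lower number that less compound is needed), compound 1 gives 610 nM, and this is the only number available, since compound 2 has no result in this assay. Within the data shown here, compound 1 therefore stands alone; no step between measured compounds can be read from the data.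

Compound 3 is obtained from compound 1 by a single change: amino in place of morpholin-4-yl on a carbonyl carbon. Amino in place of morpholin-4-yl on a carbonyl carbon is a modest change at the edge of the shared core, and with no measured pair to guide the direction, the step expected in this assay from compound 1 to compound 3 is a 1.2-fold lower number from compound 1 to compound 3 (0.09 log units; within the scatter), which is not expected to exceed the scatter of repeated measurements. Compound 3 is accordingly expected to give about 500 nM in this assay, within a range from 150 nM to 1700 nM.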

Compound 3, half-maximal effective concentration: 3200 nM
Compound 3: middle estimate off by 6.4-fold (0.81 log units), on the low side, outside the stated range (above it).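

In this assay, within the data shown here, the group on the carbonyl carbon turns out not to be a silent position: amino in place of morpholin-4-yl gives a 5.2-fold higher number from compound 1 to compound 3 (0.72 log units; beyond the scatter) and so provides the first readable step. The change therefore does more than trim the edge of the shared core, as cutting the morpholin-4-yl ring back to a single nitrogen means that more compound is needed for the effect. Nothing measured on these compounds accounts for the step.

Among these compounds, the single pair cannot separate the loss of the ring from the arrival of the amino group. Dimethylamino or piperidin-1-yl on the same carbonyl carbon would speak to that question, and how such groups would compare with morpholin-4-yl remains open.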